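From methyl to trifluoromethyl on an aromatic carbon

The source may report more compounds than this note shows. Statements on the series, on what has been measured and on what is new or still open speak of the compounds shown alone.

In a physicochemical assay for solubility, read by HPLC, in phosphate buffer, with a stated time of 24 h, at pH 7.4, tested at 100 uM (a higher number here means a more soluble compound, a lower number a less soluble compound), compound 2 `Cc1ccc(Nc2c(NC(C)CCCCC(=O)NO)c(=O)c2=O)cc1` stands highest of the two measured compounds at 83000000 nM while compound 1 `Cc1ccc(Nc2c(NCCCCCC(=O)NO)c(=O)c2=O)cc1` gives 8100000 nM as the nearest value. For the measured compounds named here, compound 3 `CC(CCCCC(=O)NO)Nc1c(Nc2ccc(C(F)(F)F)cc2)c(=O)c1=O` carries trifluoromethyl in place of methyl on an aromatic carbon and no measured step covers this change. Going by the values given here, the only step, a 10-fold higher number from compound 1 to compound 2 (1.01 log units; beyond the scatter) on a saturated chain carbon, bears only on how far one change can move this assay. Among the compounds with values here, a fall of smaller size is expected, though no measured step fixes its direction, and it is estimated as a 2.8-fold lower number from compound 2 to compound 3 (0.44 log units; beyond the scatter) (beyond the scatter only narrowly). Compound 3 is expected at 30000000 nM (6000000 nM to 90000000 nM).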

Compound 3, solubility: 30000000 nM
Compound 3: middle estimate and measured number agree at the digits printed, and the stated range covers the measured number.
By their numbers in this assay, from the lowest: compound 1; then compound 3; then compound 2.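

At the aromatic carbon para to a large group, trifluoromethyl in place of methyl gives a 2.8-fold lower number from compound 2 to compound 3 (0.44 log units; beyond the scatter) in this assay, so this position is not silent in this read-out. That step is smaller than the change on the saturated chain carbon, a 10-fold higher number from compound 1 to compound 2 (1.01 log units; beyond the scatter), and it shows that the larger aromatic substituent is tolerated on the branched chain of compound 2.

On these data alone, whether chlorine, a methoxy group or an amine at the same aromatic carbon would fall on either side of these numbers stays open, as does the size of this step on the unbranched chain of compound 1. No measurement at hand accounts for the fall from methyl to trifluoromethyl.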